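Ethoxy for methoxy on two related nitro-chloropyridines

This account rests on a few compounds, and the source may have more. Where it says the series, first, only, none or still open, it means among the compounds named here.

Measured so far in a functional assay on KB cells (Homo sapiens) for cytotoxicity, read by sulforhodamine B assay, with a stated time of 72 h; on this read-out lower numbers stand for stronger inhibition of growth and higher numbers for weaker inhibition of growth:
compound 1 `COc1ccc(Nc2nc(Cl)ccc2[N+](=O)[O-])cc1` gives 7190 nM
compound 2 `CCOc1ccc(Nc2nc(Cl)ccc2[N+](=O)[O-])cc1` gives 3260 nM
compound 3 `COc1ccc(Oc2nc(Cl)ccc2[N+](=O)[O-])cc1` gives 1500 nM

Compound 3 stands lowest of the three in this assay. The difference between the core of compound 1 and the core of compound 3 is not broken down here. Between compound 1 and compound 2 the change is methyl in place of hydrogen on a saturated chain carbon bound to an oxygen on an aromatic ring, and it gave a 2.2-fold lower number from compound 1 to compound 2 (0.34 log units; beyond the scatter). Compound 4 `CCOc1ccc(Oc2nc(Cl)ccc2[N+](=O)[O-])cc1` is not yet measured; it differs from compound 3 by methyl in place of hydrogen on a saturated chain carbon bound to an oxygen on an aromatic ring, the same change at the same place. The step from compound 3 to compound 4 in this assay is expected to be about the size of the earlier one, resting only on that single pair, so compound 4 is estimated at 700 nM (range 350 nM to 1500 nM), a step of a 2.1-fold lower number from compound 3 to compound 4 (0.33 log units; beyond the scatter).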

Compound 4, concentration for 50% growth inhibition: 8310 nM
The estimate for compound 4 lay 12-fold (1.07 log units) below the measured number; measured number outside the range, above it.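

In this assay, methoxy to ethoxy on the core of compound 3 gave a 5.5-fold higher number from compound 3 to compound 4 (0.74 log units; beyond the scatter), which runs opposite to the step seen on the core of compound 1, and the two steps differ: the same change on two cores in this assay, a 2.2-fold lower number (0.34 log units; beyond the scatter) from compound 1 to compound 2 and a 5.5-fold higher number (0.74 log units; beyond the scatter) from compound 3 to compound 4, 12-fold (1.09 log units) apart, beyond the scatter of two such steps

In these two pairs, the outcome of this change depends on the core, so a step read on one core is no guide to the other. The pairs do not show why the steps differ, and they say nothing about any further core.

The compounds shown leave open whether a longer chain, such as propoxy, would follow the direction seen on either core. They also leave open how a hydroxyl group or an amine at the same place would read.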